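A chloro group added to compound 3

The source may hold more compounds than are shown below. What is called first, only, known or untested is meant among the compounds shown, and "the series" means these compounds.

Of the compounds shown here, three have been read so far in a functional assay on NCI-H460 cells (Homo sapiens) for inhibition, read by MTT assay, with a stated time of 24 h, tested at 1 ug/mL (on this read-out higher numbers stand for more inhibition of growth at the one concentration tested and lower numbers for less inhibition of growth), and their numbers sit close together. Compound 1 `O=C(CCCCC1CCSS1)Nc1ccc(Cl)cn1` gives 6.26% and compound 2 `O=C(CCCCC(S)CCS)Nc1ccccc1` gives 4.3% while compound 3 `O=C(CCCCC(S)CCS)Nc1ccccn1` gives 2.31% on the same read-out. Compound 3 therefore stands within the scatter of both others, and no order can be read among the three.

Compound 4 `O=C(CCCCC(S)CCS)Nc1ccc(Cl)cn1` has not yet been measured. It differs from compound 3 in one place: chloro in place of hydrogen on an aromatic carbon and the chloro sits two atoms from the ring nitrogen, para to a large group.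

For the measured compounds named here, only one measured step bears on this, and only loosely: a number 2 percentage points lower from compound 2 to compound 3 (within the scatter) and that step concerns pyridin-2-yl in place of phenyl on an amide-type nitrogen, not a chloro group. Going by the values given here, no measured step shows chloro in place of hydrogen on an aromatic carbon. Among the compounds with values here, compound 1 also carries a chloro group, but no single-place step joins it to the others, and its 6.26% stays within the scatter of them.

Nothing measured points to a step beyond the scatter in this assay in either direction. The expected outcome is a number 2.2 percentage points higher from compound 3 to compound 4 (within the scatter) and no more. For compound 4 the estimate is 4.5% with 0% to 13% as the expected range.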

Compound 4, percent growth inhibition at one concentration: "not active" (no number reported)
Compound 4 has no reported number here; there is nothing to compare the estimate with.
By their numbers in this assay, from the lowest: compounds 3, 2 and 1 (each within the scatter of the next).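

In this assay, for the compounds shown here, compound 4 is reported as not active, without a number, so no step from compound 3 to compound 4 can be read. The compounds shown leave open what chloro in place of hydrogen on the aromatic carbon does on this read-out. Nothing shown offers an explanation for this result.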